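Swapping a methoxy for a sulfonamide-bearing chain on the piperidine

This account rests on a few compounds, and the source may have more. Where it says the series, first, only, none or still open, it means among the compounds named here.

Of the compounds shown here, two sharing one core have been tested in a functional assay for antagonist activity at 5-hydroxytryptamine receptor 4 (Rattus norvegicus); a higher number here means a more potent compound, by a factor of ten per unit of this negative logarithm, a lower number a less potent compound. Compound 1 `COc1cc(COc2cc(N)c(Cl)cc2C(=O)CCCCN2CCC(O)CC2)cc(OC)c1` gives 8.3. Compound 2 `COc1cc(COc2cc(N)c(Cl)cc2C(=O)CCCCN2CCC(OC)CC2)cc(OC)c1` gives 8.4. Within the data shown here, the only change between them, a number 0.10 log units higher from compound 1 to compound 2 (within the scatter), shows that this position tolerates a methyl on its oxygen without a shift beyond noise. Compound 2 thus sits essentially level with compound 1, and nothing separates the two in this assay . Compound 3 `COc1cc(COc2cc(N)c(Cl)cc2C(=O)CCCCN2CCC(CCNS(C)(=O)=O)CC2)cc(OC)c1` has not yet been measured. Its difference from compound 2 is 2-(methanesulfonamido)ethyl in place of methoxy on a saturated ring carbon. Among the measured compounds shown here, only the step from compound 1 to compound 2 touches this position, and it was within the scatter; no measured step tells how the group entering here is received. A step of about no change at the digits printed from compound 2 to compound 3 (within the scatter) is therefore expected, meaning no change beyond the scatter. Compound 3 is estimated at 8.4, with a range from 7.6 to 9.2.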

Compound 3, negative logarithm of the antagonist equilibrium constant: 8.1
Compound 3: middle estimate off by 0.30 log units, on the high side, and the stated range covers the measured number.
By their numbers in this assay, from the lowest: compounds 3, 1 and 2 (each within the scatter of the next).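

In this assay, among these compounds, the earlier pair showed only that this ring carbon accepts a methyl on its oxygen, whereas 2-(methanesulfonamido)ethyl is a far bigger change, with 7 heavy atoms against the 2 of methoxy and 1 hydrogen-bond donor where methoxy has none. Even so, the result is a number 0.30 log units lower from compound 2 to compound 3 (within the scatter), and measured against the hydroxy compound it is a number 0.20 log units lower from compound 1 to compound 3 (within the scatter), so this position takes the whole chain with no shift that can be told from noise. Nothing at hand explains why the number holds.

Still open, going by these compounds, is whether the sulfonamide itself plays any part, which a plain ethyl group on the same carbon would help to test. It is also unknown how an amine or a carboxylic acid at the end of this chain, or a longer chain, would fare here.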